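Swapping the Aromatic Group on the Shared Core

A few compounds are considered here, and "the series" means these few. Any claim that something is new, unique, unknown or untested is made for them only; others in the source may bear on it.

Compound 2 `COc1ccc(F)cc1Nc1cc(NC(=O)Nc2c(Cl)cccc2Cl)ncn1` shares its core with compound 1 `Cc1ccc(Nc2cc(NC(=O)Nc3c(Cl)cccc3Cl)ncn2)cc1F` and differs only in the group on a ring nitrogen. In a functional assay on NCI-H1581 cells (Homo sapiens) for inhibition, read by MTT assay, with a stated time of 48 h, tested at 10 uM (on this read-out higher numbers stand for more inhibition at the one concentration tested (going by the name of the read-out) and lower numbers for less inhibition), compound 2 gives 73.1%, the higher of the two numbers, while compound 1 gives 45.3%. That single change produced a number 27.8 percentage points higher from compound 1 to compound 2 (beyond the scatter). Compound 3 `Cc1ccc(Nc2cc(NC(=O)Nc3c(Cl)cccc3Cl)ncn2)cc1C` differs from compound 2 as follows: 3,4-dimethylphenyl in place of 5-fluoro-2-methoxyphenyl on a nitrogen on an aromatic ring. In this group compound 3 resembles compound 1 more than the group it replaces. A drop back toward the earlier level is therefore expected for compound 3, a number 25.1 percentage points lower from compound 2 to compound 3 (beyond the scatter). Compound 3 is estimated at 48%, within 25% to 70%.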

Compound 3, a percentage reported as inhibition, at one concentration (the size of the read-out at that concentration, not a potency): 73.3%
Compound 3: middle estimate off by 25.3 percentage points, on the low side; the measured number lies above the stated range.
By their numbers in this assay, from the lowest: compound 1; then compounds 2 and 3 (each within the scatter of the next).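

Methyl in place of fluoro on an aromatic carbon gives a number 28 percentage points higher from compound 1 to compound 3 (beyond the scatter) in this assay, so this one small swap on the ring is enough to produce a clear step. 3,4-dimethylphenyl in place of 5-fluoro-2-methoxyphenyl gives a number 0.2 percentage points higher from compound 2 to compound 3 (within the scatter), so a ring carrying only methyl groups reads the same as one carrying methoxy and fluoro. Nothing available explains these results. Going by these compounds, it remains open whether an amine or a carboxylic acid on this ring would keep the number at this level.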